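The source may hold more compounds than are shown below. What is called first, only, known or untested is meant among the compounds shown, and "the series" means these compounds.

Working notes on the series. Compound 3 `Cc1ccc(-c2nnn(CC(=O)Nc3cc(C)nn3C3CCCCC3)n2)cc1` gives 111 nM in an assay on HEK293 cells for activation of Kir3.1/Kir3.2 (Homo sapiens), read by thallium flux (on this read-out higher numbers stand for an effect only at larger amounts of compound and lower numbers for an effect already at smaller amounts), the lowest of the three numbers available. Compound 2 `Cc1cc(NC(=O)Cn2nnc(-c3ccc(F)cc3)n2)n(C2CCCCC2)n1` gives 180 nM in this assay, and compound 1 `Cc1cc(NC(=O)Cn2nnc(-c3cccc(Cl)c3)n2)n(C2CCCCC2)n1` gives 300 nM. The step of a 2.7-fold lower number from compound 1 to compound 3 (0.43 log units; beyond the scatter) is beyond the scatter, while a 1.6-fold lower number from compound 2 to compound 3 (0.21 log units; within the scatter) and a 1.7-fold lower number from compound 1 to compound 2 (0.22 log units; within the scatter) are not.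

Compound 4 `COc1cccc(-c2nnn(CC(=O)Nc3cc(C)nn3C3CCCCC3)n2)c1` has not yet been measured in this assay. Relative to compound 3 the change is 3-methoxyphenyl in place of 4-methylphenyl on an aromatic carbon.

Bearing on this step: the only measured change at the same aromatic carbon that moved beyond the scatter is a 2.7-fold lower number from compound 1 to compound 3 (0.43 log units; beyond the scatter), where a 3-chlorophenyl gave the higher number and a 4-methylphenyl the lower one. Among the measured compounds shown here, compound 4 again carries a group on the phenyl ring named 3-methoxyphenyl, but that group is a methoxy, not a chloro, and no measured pair shows a methoxy anywhere. The fluoro-to-methyl exchange in a 1.6-fold lower number from compound 2 to compound 3 (0.21 log units; within the scatter) stayed within the scatter.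

The expectation for compound 4 is therefore a number somewhat higher than that of compound 3, but the step of a 1.8-fold higher number from compound 3 to compound 4 (0.26 log units; within the scatter) is expected to stay near the edge of the scatter. Compound 4 is estimated at 200 nM, with a range from 80 nM to 500 nM.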

Compound 4, half-maximal effective concentration: 117 nM
Compound 4: middle estimate off by 1.7-fold (0.23 log units), on the high side, and the stated range covers the measured number.
By their numbers in this assay, from the lowest: compounds 3, 4, 2 and 1 (each within the scatter of the next, the first and the last beyond it).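

In this assay the exchange of 4-methylphenyl for 3-methoxyphenyl on this aromatic carbon of the five-membered ring gives a 1.1-fold higher number from compound 3 to compound 4 (0.02 log units; within the scatter) and a 1.5-fold lower number from compound 2 to compound 4 (0.19 log units; within the scatter), so compound 4 cannot be told apart from compound 3 or compound 2, although the entering group adds an oxygen and a hydrogen-bond acceptor. Among the compounds shown here, the exchange of chloro for methoxy gives a 2.6-fold lower number from compound 1 to compound 4 (0.41 log units; beyond the scatter), so the earlier link between a substituent named at the 3 position of the phenyl and the highest number does not hold for compound 4, and compound 1 remains the only compound with that higher number. Nothing at hand accounts for these steps.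

All four compounds carry one substituent on a phenyl group, which leaves open whether an amine, a carboxylic acid or a longer chain on that ring would stay close to these numbers. The higher number of compound 1 also rests on a single chloro-bearing compound, so whether it belongs to chloro more generally remains unresolved.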